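Halogen exchange on the aryl oxadiazole arm

The source may report more compounds than this note shows. Statements on the series, on what has been measured and on what is new or still open speak of the compounds shown alone.

Measured compounds in a functional assay on HCT-116 cells (Homo sapiens) for positive allosteric modulation, read by MTT assay, with stated times of 24 h and 48 h, tested at 2.5 uM; a lower number here means less inhibition of growth, a higher number more inhibition of growth at the concentration tested:
compound 1 `N#Cc1ccc(-c2cnc3[nH]cc(-c4nnc(-c5ccc(F)cc5)o4)c(=O)c3c2)cc1`, 25.6%
compound 2 `O=c1c(-c2nnc(-c3ccc(F)cc3)o2)c[nH]c2ncc(-c3cccnc3)cc12`, 20.1%
compound 3 `Cc1ccc(-c2nnc(-c3c[nH]c4ncc(-c5ccc(S(C)(=O)=O)cc5)cc4c3=O)o2)cc1`, 54.8%

Compound 1 stands second highest of the three numbers. Compound 2 sits closest to it, the step of a number 5.5 percentage points lower from compound 1 to compound 2 (within the scatter) lying within the scatter. Compound 3 is furthest, beyond the scatter, but it differs from compound 1 in two places, so that gap yields no single-change reading.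

Compound 4 `N#Cc1ccc(-c2cnc3[nH]cc(-c4nnc(-c5ccc(Cl)cc5)o4)c(=O)c3c2)cc1` differs from compound 1 by chloro in place of fluoro on an aromatic carbon, at a place para to a large group. Within the data shown here, no measured step touches this halogen; the only single-change step known, on the other arm, stayed within the scatter. The change is small and keeps donor and acceptor counts unchanged, so no step beyond the scatter is expected in this assay : a number 2.4 percentage points higher from compound 1 to compound 4 (within the scatter). Compound 4 is therefore estimated at 28%, with a range from 15% to 42%.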

Compound 4, percent growth inhibition at one concentration: 35.4%
Compound 4: middle estimate off by 7.4 percentage points, on the low side; low and high end bracket the measured number.
By their numbers in this assay, from the lowest: compounds 2, 1 and 4 (each within the scatter of the next, the first and the last beyond it); then compound 3.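

Chloro in place of fluoro, para to a large group, gives a number 9.8 percentage points higher from compound 1 to compound 4 (within the scatter) in this assay, the first single-change step read at this halogen. The exchange of 4-fluorophenyl to 4-chlorophenyl therefore leaves the growth inhibition of compound 4 within the scatter of compound 1. No supporting evidence bears on this result.

Open, on these data alone, is whether bromo, methoxy or an amine at this place would give a step beyond the scatter. Also open, as far as these compounds go, is whether the chloro exchange reads the same with pyridin-3-yl on the other arm, as carried by compound 2.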